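Swapping the para group of compound 1 for tert-butyl

The source may hold more compounds than are shown below. What is called first, only, known or untested is meant among the compounds shown, and "the series" means these compounds.

Compound 1 `Oc1nc2nonc2nc1Nc1ccc(OCC(F)(F)F)cc1` gives 42300 nM in an assay on mitochondria from L6 cells (Rattus norvegicus) for activation, with a stated time of 90 min (a higher number here means that more compound is needed for the effect, a lower number that less compound is needed), and stands highest of the three numbers measured. The two measured steps both keep its 2,2,2-trifluoroethoxy and add a group elsewhere on the ring: compound 2 `Oc1nc2nonc2nc1Nc1ccc(OCC(F)(F)F)c(F)c1` gives 10400 nM, a step of a 4.1-fold lower number from compound 1 to compound 2 (0.61 log units; beyond the scatter), and compound 3 `Oc1nc2nonc2nc1Nc1ccc(OCC(F)(F)F)c(C(F)(F)F)c1` gives 4000 nM, a step of an 11-fold lower number from compound 1 to compound 3 (1.02 log units; beyond the scatter); between them, a 2.6-fold lower number from compound 2 to compound 3 (0.41 log units; beyond the scatter). Compound 4 `CC(C)(C)c1ccc(Nc2nc3nonc3nc2O)cc1` differs from compound 1 by tert-butyl in place of 2,2,2-trifluoroethoxy on an aromatic carbon. No measured step touches this part of the ring, so nothing shown predicts the direction; the expected step from compound 1 to compound 4 is a 1.1-fold lower number from compound 1 to compound 4 (0.05 log units; within the scatter), within the scatter. Compound 4 is estimated at 38000 nM, expected between 10000 nM and 130000 nM.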

Compound 4, half-maximal effective concentration: 3900 nM
The estimate for compound 4 lay 9.7-fold (0.99 log units) above the measured number, outside the stated range (below it).
By their numbers in this assay, from the lowest: compounds 4 and 3 (each within the scatter of the next); then compound 2; then compound 1.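

In this assay, going by these compounds alone, tert-butyl in place of 2,2,2-trifluoroethoxy gives an 11-fold lower number from compound 1 to compound 4 (1.04 log units; beyond the scatter) and so shows that this aromatic carbon, left unchanged in the earlier steps, also affects the number. A group of carbon only, with no hydrogen-bond acceptor, is accepted here. No measured evidence explains the step.

As far as these compounds go, whether an amine, a carboxylic acid or a longer alkyl chain at this carbon would follow tert-butyl remains open. Also open, from the compounds shown here alone, is whether fluoro or trifluoromethyl added to compound 4 would lower the number further.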